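Notes on compound 4 against compound 1

This account rests on a few compounds, and the source may have more. Where it says the series, first, only, none or still open, it means among the compounds named here.

Compound 1 `CCNCc1cc(-c2c(C(=O)NCC)noc2-c2cc(C(C)C)c(O)cc2O)on1` gives 45 nM in a functional assay on HCT-116 cells (Homo sapiens) for inhibition (a lower number here means a stronger inhibitor, a higher number a weaker inhibitor), and stands second highest of the three numbers measured: compound 3 `CCNC(=O)c1noc(-c2cc(C(C)C)c(O)cc2O)c1-c1cnn(CC)c1` gives 26 nM, and compound 2 `CCCN(CCC)Cc1cc(-c2c(C(=O)NCC)noc2-c2cc(C(C)C)c(O)cc2O)on1` gives 183 nM. The step of a 4.1-fold higher number from compound 1 to compound 2 (0.61 log units; beyond the scatter) lies beyond the scatter, whereas the step of a 1.7-fold lower number from compound 1 to compound 3 (0.24 log units; within the scatter) does not. Compound 4 `CCNC(=O)c1noc(-c2cc(C(C)C)c(O)cc2O)c1-c1cnn(C(C)C)c1` differs from compound 1 by 1-isopropyl-1H-pyrazol-4-yl in place of 3-((ethylamino)methyl)-1,2-oxazol-5-yl on an aromatic carbon. The step of a 1.7-fold lower number from compound 1 to compound 3 (0.24 log units; within the scatter) is the one that bears on this change, as it removes the same group in favour of 1-ethyl-1H-pyrazol-4-yl and stays within the scatter; the step to compound 2 concerns a different part of the molecule. Compound 4 is therefore expected to show a 1.5-fold lower number from compound 1 to compound 4 (0.18 log units; within the scatter), nothing beyond the scatter, with an estimate of 30 nM and a range of 10 nM to 90 nM.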

Compound 4, half-maximal inhibitory concentration: 21 nM
Compound 4: middle estimate off by 1.4-fold (0.15 log units), on the high side; the measured number falls inside the stated range.
By their numbers in this assay, from the lowest: compounds 4, 3 and 1 (each within the scatter of the next, the first and the last beyond it); then compound 2.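

In this assay, 1-isopropyl-1H-pyrazol-4-yl in place of 3-((ethylamino)methyl)-1,2-oxazol-5-yl gives a 2.1-fold lower number from compound 1 to compound 4 (0.33 log units; beyond the scatter), a modest step past the scatter that the change to 1-ethyl-1H-pyrazol-4-yl did not reach. The added methyl, a 1.2-fold lower number from compound 3 to compound 4 (0.09 log units; within the scatter), stays within the scatter, so ethyl and isopropyl on the pyrazole nitrogen cannot be told apart here.

Going by these compounds, whether a longer chain on that nitrogen, or an ethylaminomethyl group on the pyrazole, would keep the number in this range remains open. Nothing available gives a reason for either step.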